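A few compounds are considered here, and "the series" means these few. Any claim that something is new, unique, unknown or untested is made for them only; others in the source may bear on it.

Compound 1 `Cc1ccc(C(=O)N[C@H]2CCN(Cc3ccc(OCCCN(C)C)cc3)C2)cc1C` is known in an assay on HEK293 cells for binding affinity to Urotensin-2 receptor (Homo sapiens), read by radioligand binding (on this read-out lower numbers stand for stronger inhibition and higher numbers for weaker inhibition), only as a limit, < 10000 nM, not as a number. Compound 2 `CN(C)CCCOc1ccc(CN2CC[C@H](NC(=O)c3ccccc3)C2)cc1`, which carries phenyl in place of 3,4-dimethylphenyl on the carbonyl carbon, gives 2510 nM in this assay. The step from compound 1 to compound 2 is a step that the limit leaves unreadable from compound 1 to compound 2 because of the limit of < 10000 nM in this assay, at which 1 of the 2 values shown sits. Compound 3 `CN(C)CCCOc1ccc(CN2CC[C@H](NC(=O)c3ccncc3)C2)cc1` differs from compound 1 by pyridin-4-yl in place of 3,4-dimethylphenyl on a carbonyl carbon. Among the compounds with values here, no measured step reads clearly, so the size of the change cannot be anticipated from the data. Compound 3 is expected to give about 3500 nM in this assay, within 800 nM to 12000 nM, an estimated step that the limit leaves unreadable from compound 1 to compound 3 from compound 1.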

Compound 3, inhibition constant: < 10000 nM
Compound 3 gave a limit, no number; the forecaster's own chance of this, stated with the estimate: 30%; the middle value is on the limit's open side.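

No new step can be read from compound 3 to compound 1 or compound 2, because compound 3 gives only a limit: the limit of < 10000 nM in this assay, at which 2 of the 3 values shown sit. On these data alone, whether pyridin-4-yl on the carbonyl carbon strengthens or weakens inhibition compared with phenyl or 3,4-dimethylphenyl stays open.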